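Trading an ethynyl group for a methyl group

This account rests on a few compounds, and the source may have more. Where it says the series, first, only, none or still open, it means among the compounds named here.

Among the compounds with values here, in a functional assay on MIA PaCa-2 cells (Homo sapiens) for antiproliferative activity (a higher number here means that more compound is needed for the effect, a lower number that less compound is needed), only two compounds have numbers so far. Compound 1 `Cc1cc2c(C(N)=O)cccc2n1-c1nc2c(c(NCc3ccccc3)n1)COCC2` gives 146 nM in this test. Compound 2 `C#CCCNC(=O)c1cccc2c1cc(C)n2-c1nc2c(c(NCc3ccccc3)n1)CCCC2` gives 1410 nM and so holds the higher of the two numbers, a gap beyond the scatter. More of compound 2 is therefore needed for the same effect. The two compounds differ in more than one place, so this gap cannot be tied to any single change.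

Compound 3 `CCCNC(=O)c1cccc2c1cc(C)n2-c1nc2c(c(NCc3ccccc3)n1)CCCC2` differs from compound 2 in one place only methyl in place of ethynyl on a saturated chain carbon, two bonds along the chain from an amide-type nitrogen with methyl in place of ethynyl on a saturated chain carbon, two bonds along the chain from an amide-type nitrogen. The but-3-yn-1-yl group thus becomes propyl. Within the data shown here, no measured pair shows this change on its own, so any forecast is cautious. Compound 2 at 1410 nM is the natural starting point for the forecast. The estimated step of a 1.2-fold lower number from compound 2 to compound 3 (0.07 log units; within the scatter) is expected to stay within the scatter, with no firm direction. For compound 3 the expected value is 1200 nM in this test, with an estimated range from 450 nM up to 3200 nM in this assay as well.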

Compound 3, half-maximal effective concentration: 608 nM
Compound 3: middle estimate off by 2.0-fold (0.30 log units), on the high side; the measured number falls inside the stated range.
By their numbers in this assay, from the lowest: compound 1; then compound 3; then compound 2.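

Within the data shown here, this is the first pair in this assay that differs in one place only, so a gap can now be tied to a single change: going from but-3-yn-1-yl to propyl gives a 2.3-fold lower number from compound 2 to compound 3 (0.37 log units; beyond the scatter) on this shared core. At this position on the amide nitrogen, then, the triple bond at the end of the chain is not needed for the antiproliferative effect, and the saturated chain, one carbon shorter, does modestly better, on the strength of this one pair. No measurement at hand explains the step, so it stands as an observation only.

Going by these compounds, whether an amine, a carboxylic acid or a longer chain at this spot would move the number further remains open, as does the effect of shortening the chain further, all the way to the plain amide carried by compound 1, which differs from compound 3 in more than one place. A single pair also cannot show whether methyl in place of ethynyl would act the same way on another core, such as that of compound 1.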